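Adding a nitro group to compound 1

The source may hold more compounds than are shown below. What is called first, only, known or untested is meant among the compounds shown, and "the series" means these compounds.

Values measured so far in a functional assay on SW982 cells (Homo sapiens) for inhibition, read by MTT assay, with a stated time of 72 h (a lower number here means a stronger inhibitor, a higher number a weaker inhibitor), are these:
Compound 1 `COc1cc(OC)c(OC)cc1/C=C/C(=O)c1ccc(Cl)cc1` gives 58500 nM
Compound 2 `COc1cc(OC)c(OC)cc1/C=C/C(=O)c1cc(Cl)ccc1O` gives > 150000 nM (a limit of the assay)
Compound 3 `COc1cc(OC)c(OC)cc1/C=C/C(=O)c1ccc(F)cc1` gives 32500 nM

In this assay compound 1 gives 58500 nM and has compound 3 as its nearest neighbour, with a 1.8-fold lower number from compound 1 to compound 3 (0.26 log units; within the scatter) as the gap. The value of compound 2 is only a limit.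

Compound 4 `COc1cc(OC)c(OC)cc1/C=C/C(=O)c1ccc(Cl)c([N+](=O)[O-])c1` keeps the core of compound 1 and differs by one group, nitro in place of hydrogen on an aromatic carbon, as counted in nitro in place of hydrogen on an aromatic carbon here. Going by the values given here, no measured step adds a nitro group. The closest guidance comes from two steps that alter the same aromatic ring. One is a 1.8-fold lower number from compound 1 to compound 3 (0.26 log units; within the scatter) and the other, which ends at a limit, is an at least 2.5-fold higher number from compound 1 to compound 2 (0.40 log units; beyond the scatter) in size. These two steps give no firm direction, so no step beyond the scatter is expected in this assay. The expected change is a 1.1-fold higher number from compound 1 to compound 4 (0.05 log units; within the scatter) as estimated. Compound 4 is estimated at 65000 nM within a range of 25000 nM to 150000 nM as its expected span.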

Compound 4, half-maximal inhibitory concentration: 20600 nM
Beside the measured number, compound 4's estimate is 3.2-fold (0.50 log units) above it, and the stated range ends above it.
By their numbers in this assay, from the lowest: compounds 4, 3 and 1 (each within the scatter of the next, the first and the last beyond it). At a limit, above all of these: compound 2.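

In this assay, a nitro group on the aromatic carbon ortho to a chloro group, with that chloro group kept, gives a 2.8-fold lower number from compound 1 to compound 4 (0.45 log units; beyond the scatter), the first step shown from compound 1 that lowers the number beyond the scatter. Going by these compounds alone, the only earlier step from compound 1 beyond the scatter, an at least 2.5-fold higher number from compound 1 to compound 2 (0.40 log units; beyond the scatter), ended at a limit of the assay and ran the other way. This aromatic carbon therefore accepts a group of 3 heavy atoms with a lower number as the result, but nothing measured here gives a reason for the change.

Going by these compounds, whether an amine or a nitrile on the same aromatic carbon would move the number as nitro does stays open. So does whether nitro gives a similar step with fluoro in place of the chloro group, as in compound 3.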